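The source may report more compounds than this note shows. Statements on the series, on what has been measured and on what is new or still open speak of the compounds shown alone.

The compounds measured so far:

compound 1, `CC1(C)[C@H]2CC[C@]1(C)N(Cc1cn(-c3cccc(F)c3)nn1)C(=O)C2`, 430 nM in a functional assay on OVCAR-3 cells (Homo sapiens) for inhibition, read by MTT assay, with a stated time of 24 h; a lower number here means a stronger inhibitor, a higher number a weaker inhibitor
compound 2, `CC1(C)[C@H]2CC[C@]1(C)N(Cc1cn(-c3ccccc3Br)nn1)C(=O)C2`, 140 nM
compound 3, `CC1(C)[C@H]2CC[C@]1(C)N(Cc1cn(-c3cccc(C#N)c3)nn1)C(=O)C2`, 230 nM

Compound 3 gives the second highest of the three numbers; its nearest neighbour is compound 2 (a 1.6-fold higher number from compound 2 to compound 3 (0.22 log units; within the scatter)), its furthest compound 1 (a 1.9-fold lower number from compound 1 to compound 3 (0.27 log units; within the scatter)), and both gaps lie within the scatter. Compound 4, `COc1ccccc1-n1cc(CN2C(=O)C[C@@H]3CC[C@@]2(C)C3(C)C)nn1`, has not yet been measured; it differs from compound 3 in a single place: 2-methoxyphenyl in place of 3-cyanophenyl on an aromatic nitrogen.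

Going by the values given here, two measured steps bear on this change. Replacing 3-fluorophenyl by 2-bromophenyl on the aromatic nitrogen gave a 3.1-fold lower number from compound 1 to compound 2 (0.49 log units; beyond the scatter), beyond the scatter, while moving from 2-bromophenyl to 3-cyanophenyl gave a 1.6-fold higher number from compound 2 to compound 3 (0.22 log units; within the scatter), within it. Compound 4 carries a 2-methoxyphenyl in that place, as compound 2 carries a 2-bromophenyl, so a small step toward a lower number, likely within the scatter, is expected: a 1.3-fold lower number from compound 3 to compound 4 (0.11 log units; within the scatter). Compound 4 is therefore estimated at 180 nM, within a range from 70 nM to 450 nM.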

Compound 4, half-maximal inhibitory concentration: 140 nM
Estimate against measurement, compound 4: 1.3-fold (0.11 log units) above, and the stated range covers the measured number.
By their numbers in this assay, from the lowest: compounds 2, 4, 3 and 1 (each within the scatter of the next, the first and the last beyond it).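

In this assay, 2-methoxyphenyl on the aromatic nitrogen cannot be told apart from 2-bromophenyl (no change at the digits printed from compound 2 to compound 4 (within the scatter)), so two different groups on that aromatic carbon now give the same number. Compound 4 also stands clear of the 3-fluorophenyl compound (a 3.1-fold lower number from compound 1 to compound 4 (0.49 log units; beyond the scatter)), matching the step seen for compound 2, but it is not separated from the 3-cyanophenyl compound (a 1.6-fold lower number from compound 3 to compound 4 (0.22 log units; within the scatter)), and compound 3 therefore goes against any clean division between the 2-substituted and 3-substituted phenyl groups. Nothing given here explains these numbers.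

As far as these compounds go, whether the place of the group on the phenyl ring matters in itself stays open, as a direct comparison would need 3-methoxyphenyl or 3-bromophenyl beside their 2-substituted partners. From the compounds shown here alone, it is also open how an amine or a carboxylic acid on that phenyl ring would compare.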